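This account rests on a few compounds, and the source may have more. Where it says the series, first, only, none or still open, it means among the compounds named here.

Of the compounds shown here, three have so far been tested in a functional assay on the whole organism (strain Sprague-Dawley) for inhibition, with Rattus norvegicus as the target; a lower number here means that less compound is needed, a higher number that more compound is needed for the effect. Compound 1 `CCc1cccc2cc(C(=O)O)cnc12` gives only a limit in this assay, > 50 mg/kg, and no exact number. Compound 2 `Fc1ccc2ncc(-c3nn[nH]n3)cc2c1` also gives only a limit in this assay, < 25 mg/kg. Compound 3 `COc1ccc2c(=O)c(-c3nn[nH]n3)c[nH]c2c1`, built on a different core, gives 10 mg/kg in this assay. For the measured compounds named here, compound 1 therefore stands on the weak side of what has been seen: its result is a limit (the limit of > 50 mg/kg in this assay, at which 1 of the 3 values shown sits), and no compound sharing its core has yet given a number.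

Compound 4 `COc1cccc2cc(C(=O)O)cnc12` differs from compound 1 in one place: methoxy in place of ethyl on an aromatic carbon. Going by the values given here, no pair of measured compounds shows what this swap does in this assay, so the size of the step is not known from the data. Exchanging one small group for another of matching size suggests no step beyond the usual scatter, in either direction. Compound 4 is therefore expected to give about 60 mg/kg, with a likely range from 25 mg/kg to 150 mg/kg. The step this estimate means, a step that the limit leaves unreadable from compound 1 to compound 4, is expected to be small, and a limit rather than a number is again the most likely outcome.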

Compound 4, minimum effective dose: 25 mg/kg
Estimate against measurement, compound 4: 2.4-fold (0.38 log units) above, and the stated range covers the measured number.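

Methoxy in place of ethyl, on an aromatic carbon ortho to a fused ring and meta to a fused ring, gives an exact number for the shared core: in this assay compound 4 gives 25 mg/kg. The change reads as an at least 2.0-fold lower number from compound 1 to compound 4 (0.30 log units; that floor lies within the scatter), so the true step may be larger, but the part that can be stated does not go beyond the scatter. The step has only a floor because compound 1 is known only through a limit: the limit of > 50 mg/kg in this assay, at which 1 of the 4 values shown sits.

The compounds shown leave open how the number would move with other groups at this carbon, such as a hydroxyl, a chlorine or a longer chain like propyl. For the compounds shown here, no second pair shows whether the same swap would give a similar step on a different core.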